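Fluoro on the aryl ring and hepatocyte clearance

The compounds below may be only part of what the source reports. "The series", "measured", "known", "first", "only" and "open" are said of these compounds alone.

Compound 1 `COc1nc(C2=NOCC(c3ccc(C(F)(F)F)cc3)N2)ccc1-n1cnc(C)c1` is the starting point of this small series. In an ADME assay on cells (Hepatocyte, Homo sapiens) for pharmacokinetics (a lower number here means slower removal, a higher number faster removal of the compound), compound 1 gives 12 mL/min/kg. Compound 2 `COc1nc(C2=NOCC(c3ccc(C(F)(F)F)c(F)c3)N2)ccc1-n1cnc(C)c1` carries the change fluoro in place of hydrogen on an aromatic carbon and in this assay compound 2 gives 62 mL/min/kg, so the step of a 5.2-fold higher number from compound 1 to compound 2 (0.71 log units; beyond the scatter) is clear. Compound 3 `COc1nc(C2=NOC(C)C(c3ccc(Cl)cc3)N2)ccc1-n1cnc(C)c1` has a different core; the difference between the two cores is not broken down here. In this assay compound 3 gives 12 mL/min/kg, level with compound 1 within the scatter and well below compound 2.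

Compound 4 `COc1nc(C2=NOC(C)C(c3ccc(Cl)c(F)c3)N2)ccc1-n1cnc(C)c1` is not yet measured and differs from compound 3 by fluoro in place of hydrogen on an aromatic carbon. This is the same kind of change as in the earlier pair, but not the same: there the entering fluoro sat ortho to a trifluoromethyl group, here it sits ortho to a chloro group. For the measured compounds named here, the step expected from compound 3 to compound 4 in this assay is a 2.9-fold higher number from compound 3 to compound 4 (0.46 log units; beyond the scatter), resting on the single earlier step of a 5.2-fold higher number from compound 1 to compound 2 (0.71 log units; beyond the scatter), tempered because only one example exists. Compound 4 is therefore estimated at 35 mL/min/kg, spanning 14 mL/min/kg to 80 mL/min/kg.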

Compound 4, clearance: 1 mL/min/kg
Estimate against measurement, compound 4: 35-fold (1.54 log units) above, and the stated range ends above it.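

In this assay, replacing hydrogen with fluoro on the aromatic ring now gives a 12-fold lower number from compound 3 to compound 4 (1.08 log units; beyond the scatter). Set beside the earlier step, this shows that the change does not carry over from one core to the other in either direction or size: the same change on two cores in this assay, a 5.2-fold higher number (0.71 log units; beyond the scatter) from compound 1 to compound 2 and a 12-fold lower number (1.08 log units; beyond the scatter) from compound 3 to compound 4, 62-fold (1.79 log units) apart, beyond the scatter of two such steps. It does not show which difference reverses the step, as the two pairs differ in their core and also in the group on the aryl ring, trifluoromethyl in one pair and chloro in the other, and a single pair on each side supports no rule for the series.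

The compounds shown leave open whether the outcome follows the core or the aryl group, a question that chloro on the core of compound 1, or trifluoromethyl on the core of compound 3, would help to separate. Also open, going by these compounds, is how the same fluoro would behave alongside another group in that place, such as a nitrile or a bromine atom.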